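Swapping methylsulfanyl for nitro on compound 1

The source may report more compounds than this note shows. Statements on the series, on what has been measured and on what is new or still open speak of the compounds shown alone.

In an ADME assay on BJ cells (Homo sapiens) for cytotoxicity, with a stated time of 72 h (a higher number here means that more compound is needed for the effect, a lower number that less compound is needed), compound 1 (`CSc1ccccc1NC(=O)Nc1cc(C)nc2ccccc12`) gives > 25000 nM, which is a limit of the assay and not a number. Compound 2 (`Cc1cc(NC(=O)Nc2ccc(C(=O)O)cc2)c2ccccc2n1`) gives > 25000 nM, and this too is a limit. The two results therefore share one ceiling, (the limit of > 25000 nM in this assay, at which 2 of the 2 values shown sit), and neither compound has a true number yet.

Compound 3 (`Cc1cc(NC(=O)Nc2ccccc2[N+](=O)[O-])c2ccccc2n1`) keeps the core of compound 1 but carries nitro in place of methylsulfanyl on an aromatic carbon, ortho to a large group (nitro in place of methylsulfanyl on an aromatic carbon).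

Among the measured compounds shown here, no two measured compounds differ in just one place, so the data offer no direct guide to the size of such a step. The only support is that both compounds measured in this assay sit at the limit, even though their structures differ. No shift beyond the usual scatter is therefore expected, and another result reported only as a limit is the likeliest outcome. The estimated step, a number no higher from compound 1 to compound 3 (the limit leaves the size open), reflects that expectation. For compound 3 the expected value is 25000 nM, with an estimated range from 10000 nM to 40000 nM.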

Compound 3, half-maximal effective concentration: > 25000 nM
Compound 3: only a limit was reported; the forecaster's own chance of this, stated with the estimate: 75%; the middle value lies on the limit itself.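

The change from compound 1 to compound 3 cannot be read as a step, because both results are limits and not numbers: the limit of > 25000 nM in this assay, at which 3 of the 3 values shown sit.

The compounds shown leave open how far each one lies beyond that limit, and whether nitro and methylsulfanyl give different values at all in this assay.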